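Methoxy for Fluoro on a Benzoate Ester

The source may report more compounds than this note shows. Statements on the series, on what has been measured and on what is new or still open speak of the compounds shown alone.

Measured so far:
compound 1 `CN1CCC(OC(=O)c2ccccc2F)CC1`, 1.41
compound 2 `Cc1ccc(C)c(C(=O)OC2CCN(C)CC2)c1`, 1.36

Of the compounds shown here, two share an ester core and have been tested in a functional assay on the whole organism with Mus musculus as the target; a higher number here means a more potent compound, by a factor of ten per unit of this negative logarithm, a lower number a less potent compound. Compound 1, with a fluoro group on its aromatic ring, gives 1.41. Compound 2, which carries two methyl groups on its ring instead, gives 1.36. Compound 1 has the higher of the two numbers, yet the gap to compound 2 lies within the scatter of repeated measurements, so the two cannot be told apart on these data.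

The next compound, compound 3 `COc1ccccc1C(=O)OC1CCN(C)CC1`, has not yet been tested in this assay. It differs from compound 1 in one place: methoxy in place of fluoro on an aromatic carbon.

Within the data shown here, no step between measured compounds is available to guide this change. Among the measured compounds shown here, since the only comparison at hand, between the fluoro compound 1 and the dimethyl compound 2, shows no difference beyond the scatter, the expectation for compound 3 is a step from compound 1 of no more than the scatter in either direction, a number 0.01 log units lower from compound 1 to compound 3 (within the scatter). Compound 3 is estimated at 1.4, with a range from 1 to 1.8.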

Compound 3, logarithm of the reciprocal of the active concentration, log(1/C): 1.43
Estimate against measurement, compound 3: 0.03 log units below; the range from low to high includes it.
By their numbers in this assay, from the lowest: compounds 2, 1 and 3 (each within the scatter of the next).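

Among these compounds, replacing fluoro with methoxy on an aromatic carbon ortho to a large group gives a number 0.02 log units higher from compound 1 to compound 3 (within the scatter) in this assay, and this is the first comparison here between two compounds that differ in only one place. Unlike the earlier comparison of compound 1 and compound 2, which differ in more than one place, this step isolates a single change: two heavy atoms, including a hydrogen-bond acceptor, enter where one fluorine atom leaves, and the number stays within the scatter. No available measurement bears on why the two groups read alike.

Still open, on these data alone, is whether an amine, a carboxylic acid or a longer chain such as butoxy on this same aromatic carbon would also stay within the scatter of compound 1, or would produce a step large enough to read with confidence. This single pair also cannot show whether methoxy in place of fluoro would give a similar result at another carbon of the aromatic ring or on a different core.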